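The source may report more compounds than this note shows. Statements on the series, on what has been measured and on what is new or still open speak of the compounds shown alone.

Of the compounds shown here, three have so far been measured in a physicochemical assay for lipophilicity; a higher number here means a more lipophilic compound, a lower number a more polar compound. Compound 1 `COc1cc(/C=C2\CCC/C(=C\c3ccccc3[N+](=O)[O-])C2=O)cc(OC)c1OC` gives 4.86. For the measured compounds named here, compound 3 `COc1cc(/C=C2\CCC/C(=C\c3cccc([N+](=O)[O-])c3)C2=O)cc(OC)c1OC` gives 5.06, and the step of a number 0.20 log units higher from compound 1 to compound 3 (within the scatter) is the only change between two measured compounds that differs in a single place. Compound 2 `O=C1/C(=C/c2ccc(F)cc2)CCC/C1=C\c1cccc([N+](=O)[O-])c1` gives 5.06. On these numbers compound 2 stands level with compound 3 at the digits shown, the two of them together the highest of the three values, while the gap to compound 1 is within the scatter, so no order among the three can be read from these measurements.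

The next compound, compound 4 `COc1ccc(/C=C2\CCC/C(=C\c3cccc([N+](=O)[O-])c3)C2=O)cc1`, has not yet been measured in this assay. It differs from compound 2 in one place: methoxy in place of fluoro on an aromatic carbon. Going by the values given here, no measured step follows this same change. Among the compounds with values here, the single step known concerns 3-nitrophenyl in place of 2-nitrophenyl and bears only indirectly on methoxy in place of fluoro, in that a small change in one place gave a step within the scatter. A small change is therefore expected, a number 0.16 log units lower from compound 2 to compound 4 (within the scatter), not beyond the scatter. For compound 4 the estimate in this assay is 4.9, with a range from 4.5 to 5.3.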

Compound 4, partition coefficient: 5.06
For compound 4 the middle estimate is 0.16 log units below the measured one, within the range that was stated.
By their numbers in this assay, from the lowest: compounds 1, 2, 3 and 4 (each within the scatter of the next).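

In this assay, for the compounds shown here, methoxy in place of fluoro on an aromatic carbon para to a large group, the change from 4-fluorophenyl to 4-methoxyphenyl, gives no change at the digits printed from compound 2 to compound 4 (within the scatter) and so provides the first measured step at this position, since the only earlier step concerned 3-nitrophenyl in place of 2-nitrophenyl. The two groups differ in what can be counted: fluoro has 1 heavy atom and 0 hydrogen-bond acceptors, methoxy 2 heavy atoms and 1 hydrogen-bond acceptor, yet in this single pair that difference comes with a step that stays inside the scatter. Nothing given here explains this result.

Going by these compounds, whether an amine, a carboxylic acid or a longer chain such as butoxy on this aromatic carbon would also stay within the scatter remains open. The change is seen in one pair only, so how methoxy in place of fluoro would read on another aromatic carbon, or with a different group in place of the 3-nitrophenyl, cannot be told from these compounds.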